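Swapping the aryl carbonyl group on compound 3

A few compounds are considered here, and "the series" means these few. Any claim that something is new, unique, unknown or untested is made for them only; others in the source may bear on it.

Values in a functional assay on A549 cells (Homo sapiens) for inhibition, read by MTT assay, with a stated time of 24 h; a higher number here means a weaker inhibitor of growth, a lower number a stronger inhibitor of growth:
- compound 1 `Cn1cc(-c2nc3ccccc3n2C(=O)c2cccc(Br)c2)c2ccccc21`: 34200 nM
- compound 2 `COc1ccccc1C(=O)n1c(-c2cn(C)c3ccc(Br)cc23)nc2ccccc21`: 12800 nM
- compound 3 `COc1ccc(C(=O)n2c(-c3cn(C)c4ccc(Br)cc34)nc3ccccc32)cc1OC`: 3400 nM

Compound 3 at 3400 nM holds the lowest of the three numbers, and compound 1 at 34200 nM holds the highest. Next up is compound 4 `Cn1cc(-c2nc3ccccc3n2C(=O)c2cccc(Br)c2)c2cc(Br)ccc21`, with 3-bromophenyl in place of 3,4-dimethoxyphenyl on a carbonyl carbon.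

For the measured compounds named here, one measured step bears on this change: a 3.8-fold lower number from compound 2 to compound 3 (0.58 log units; beyond the scatter). It is modest, and it is the step by which 3,4-dimethoxyphenyl entered. Compound 1 carries the same 3-bromophenyl group and gives 34200 nM, but its core differs from that of compound 3, so it offers only loose support. Losing 3,4-dimethoxyphenyl is therefore expected to raise the number in this assay by a similarly modest amount. The expected change is a 3.2-fold higher number from compound 3 to compound 4 (0.51 log units; beyond the scatter). For compound 4 the estimate is 11000 nM, with an expected range of 4000 nM to 30000 nM.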

Compound 4, concentration for 50% growth inhibition: 38500 nM
For compound 4 the middle estimate is 3.5-fold (0.54 log units) below the measured one; measured number outside the range, above it.
By their numbers in this assay, from the lowest: compound 3; then compound 2; then compounds 1 and 4 (each within the scatter of the next).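

On the shared core in this assay, the step of an 11-fold higher number from compound 3 to compound 4 (1.05 log units; beyond the scatter) is large, where the earlier step at this carbonyl carbon was modest, and a 3.0-fold higher number from compound 2 to compound 4 (0.48 log units; beyond the scatter) shows that 3-bromophenyl also gives a higher number than 2-methoxyphenyl. From the lowest number to the highest, the three groups on this core therefore run 3,4-dimethoxyphenyl, 2-methoxyphenyl, 3-bromophenyl. Bromo in place of hydrogen on an aromatic carbon gives a 1.1-fold higher number from compound 1 to compound 4 (0.05 log units; within the scatter) with 3-bromophenyl on the carbonyl carbon, so that change does not separate the two compounds in this setting.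

Nothing available explains the differences at this position.

Still open, going by these compounds, is how an amine or a carboxylic acid in place of 3,4-dimethoxyphenyl on the carbonyl carbon would compare with compound 3.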